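Swapping Methyl for Trifluoromethyl in Compound 1

The source may hold more compounds than are shown below. What is called first, only, known or untested is meant among the compounds shown, and "the series" means these compounds.

Among the compounds with values here, compound 1 `Cc1c(C(=O)Nc2ccc(Oc3ccnc4[nH]ccc34)cc2)nnn1-c1ccccc1F` is one of two compounds measured in a functional assay on HT-29 cells (Homo sapiens) for cytotoxicity, read by MTT assay, with a stated time of 72 h; on this read-out higher numbers stand for weaker inhibition and lower numbers for stronger inhibition. In this assay compound 1 gives 360 nM, the highest of the two numbers. Within the data shown here, its only measured neighbour, compound 2 `Cc1c(C(=O)Nc2ccc(Oc3ccnc4[nH]ccc34)cc2)nnn1-c1ccc(F)cc1`, carries a 4-fluorophenyl in place of the 2-fluorophenyl on the aromatic nitrogen, and in this assay compound 2 gives 180 nM. The step of a 2.0-fold lower number from compound 1 to compound 2 (0.30 log units; within the scatter) stays within the scatter. Compound 3 `O=C(Nc1ccc(Oc2ccnc3[nH]ccc23)cc1)c1nnn(-c2ccccc2F)c1C(F)(F)F` differs from compound 1 at another place: trifluoromethyl in place of methyl on an aromatic carbon. Among the measured compounds shown here, no measured step touches this methyl; the single step known here concerns the fluorophenyl and says nothing about the group on the aromatic carbon. With nothing bearing on the change, no shift beyond the scatter in this assay is expected in either direction, and the range must stay wide. Compound 3 is therefore estimated at 400 nM, between 120 nM and 1500 nM. The expected step is a 1.1-fold higher number from compound 1 to compound 3 (0.05 log units; within the scatter).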

Compound 3, half-maximal inhibitory concentration: 120 nM
Compound 3: middle estimate off by 3.3-fold (0.52 log units), on the high side, within the range that was stated.
By their numbers in this assay, from the lowest: compounds 3, 2 and 1 (each within the scatter of the next, the first and the last beyond it).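

In this assay the aromatic carbon next to the ring atom that bears a 2-fluorophenyl group proves responsive: trifluoromethyl in place of methyl gives a 3.0-fold lower number from compound 1 to compound 3 (0.48 log units; beyond the scatter) and is a modest step. The only earlier step, a 2.0-fold lower number from compound 1 to compound 2 (0.30 log units; within the scatter), concerned the fluorophenyl and stayed within the scatter, so this is the first change among these compounds to move the number beyond it. Nothing measured here accounts for the step, which stands as an observation on this single pair.

Only methyl and trifluoromethyl are shown on this carbon, so it remains open how ethyl, a chlorine atom, a nitrile or an amine would behave there. From the compounds shown here alone, it is also open whether trifluoromethyl in place of methyl would give a step of similar size with the 4-fluorophenyl of compound 2.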